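The source may report more compounds than this note shows. Statements on the series, on what has been measured and on what is new or still open speak of the compounds shown alone.

Of the compounds shown here, three sharing one core have been measured in an ADME assay on HeLa cells (Homo sapiens) for cytotoxicity, read by sulforhodamine B assay, with a stated time of 48 h, tested at 10 uM; on this read-out lower numbers stand for less inhibition and higher numbers for more inhibition at the one concentration tested (going by the name of the read-out). Compound 1 `COc1nc2ccc(Br)cc2cc1C(c1ccccc1)n1cc(-c2ccccc2F)nn1` gives 14.1%, compound 3 `COc1nc2ccc(Br)cc2cc1C(c1ccccc1)n1cc(-c2cccc(F)c2)nn1` gives 9.04%, and compound 2 `CCCCc1cn(C(c2ccccc2)c2cc3cc(Br)ccc3nc2OC)nn1` gives -2.87%, which is the lowest of the three numbers; the nearest to it is compound 3 and the furthest compound 1. Two steps between these compounds swap an aromatic group for a butyl chain or back: a number 17 percentage points lower from compound 1 to compound 2 (beyond the scatter) and a number 11.9 percentage points higher from compound 2 to compound 3 (beyond the scatter), both beyond the scatter, while a number 5.1 percentage points lower from compound 1 to compound 3 (within the scatter) stays within it.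

Compound 4 `COc1nc2ccc(Br)cc2cc1C(c1ccccc1)n1cc(-c2ccc(OC(F)(F)F)cc2)nn1` differs from compound 2 at the same place: 4-(trifluoromethoxy)phenyl in place of butyl on an aromatic carbon. Because compound 2 sits at -2.87% and both aryl-bearing compounds read higher, with a number 11.9 percentage points higher from compound 2 to compound 3 (beyond the scatter) as the closest comparison, the expected direction in this assay is upward, by a modest amount beyond the scatter. The step expected from this change is a number 14.9 percentage points higher from compound 2 to compound 4 (beyond the scatter). Compound 4 is therefore estimated at 12%, with a range from 0% to 25%.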

Compound 4, a percentage reported as inhibition, at one concentration (the size of the read-out at that concentration, not a potency): -2.24%
Compound 4: middle estimate off by 14.2 percentage points, on the high side; the whole stated range lies above it.
By their numbers in this assay, from the lowest: compounds 2 and 4 (each within the scatter of the next); then compounds 3 and 1 (each within the scatter of the next).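

Replacing butyl with 4-(trifluoromethoxy)phenyl on this aromatic carbon gives a number 0.6 percentage points higher from compound 2 to compound 4 (within the scatter) in this assay, so carrying an aromatic ring at this position does not by itself go with a higher number. The aromatic groups do not all read alike: a number 11.3 percentage points lower from compound 3 to compound 4 (beyond the scatter) and a number 16.3 percentage points lower from compound 1 to compound 4 (beyond the scatter) set 4-(trifluoromethoxy)phenyl apart from both fluorophenyl groups, and the earlier contrast between ring and chain therefore holds only for compound 1 and compound 3. Nothing available here accounts for this result.

The compounds shown leave open whether the low number of compound 4 goes with the trifluoromethoxy group itself or with where it sits on the phenyl ring. From the compounds shown here alone, how an unsubstituted phenyl, an amine or a longer chain would read on this carbon also remains open.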